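Urea for Imidazole on the Oxazolidinone Side Chain

The source may report more compounds than this note shows. Statements on the series, on what has been measured and on what is new or still open speak of the compounds shown alone.

Compound 1 `CN(CCC#N)C[C@H]1CN(c2ccc(-n3cc(-c4ccccn4)cn3)c(F)c2)C(=O)O1`: 64500 nM
Compound 2 `O=C1O[C@@H](Cn2ccnc2)CN1c1ccc(-n2cc(-c3ccccn3)cn2)c(F)c1`: 12300 nM

In a physicochemical assay for solubility, read by HPLC, with a stated time of 24 h (a higher number here means a more soluble compound, a lower number a less soluble compound), compound 2 gives the lower of the two numbers, with compound 1 set apart by a 5.2-fold lower number from compound 1 to compound 2 (0.72 log units; beyond the scatter). Compound 3 `CCNC(=O)NC[C@H]1CN(c2ccc(-n3cc(-c4ccccn4)cn3)c(F)c2)C(=O)O1` carries the change ((ethylcarbamoyl)amino in place of 1H-imidazol-1-yl on a saturated chain carbon bound to a saturated ring carbon). Going by the values given here, the only measured step swaps a different group at the same place, so it bears on compound 3 only loosely; a step of comparable size cannot be ruled out, but nothing measured points to a direction. Compound 3 is therefore expected near compound 2, with a step of a 1.4-fold lower number from compound 2 to compound 3 (0.14 log units; within the scatter), giving an estimate of 9000 nM within 3000 nM to 27000 nM.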

Compound 3, solubility: 222000 nM
Beside the measured number, compound 3's estimate is 25-fold (1.39 log units) below it, outside the stated range (above it).
By their numbers in this assay, from the lowest: compound 2; then compound 1; then compound 3.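

In this assay, this place on the side chain can move the number up as well as down: the urea gives an 18-fold higher number from compound 2 to compound 3 (1.26 log units; beyond the scatter) and also a 3.4-fold higher number from compound 1 to compound 3 (0.54 log units; beyond the scatter). Until now, only a drop had been seen here, whereas compound 3 now stands highest of the three, with its steps to both others beyond the scatter. Nothing measured explains this rise.

Going by these compounds, whether the rise belongs to the urea itself or to its ethyl group remains open. An unsubstituted urea, a methyl urea or an acetamide at this place would bear on that question.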